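Chloro to methyl: from compound 3 to compound 4

The source may hold more compounds than are shown below. What is called first, only, known or untested is meant among the compounds shown, and "the series" means these compounds.

Values measured so far in a functional assay on KB cells (Homo sapiens) for cytotoxicity, read by sulforhodamine B assay; a higher number here means a weaker inhibitor of growth, a lower number a stronger inhibitor of growth
- compound 1 `COc1ccc2c(c1)C(=O)CCN2c1nc(C)nc2ccccc12` gives 19 nM
- compound 2 `COc1ccc2c(c1)C(O)CCN2c1nc(C)nc2ccccc12` gives 18 nM
- compound 3 `COc1ccc2c(c1)CCN2c1nc(Cl)nc2ccccc12` gives 227 nM

Compound 3 (227 nM) has the highest of the three numbers and lies beyond the scatter from both of the others. Compound 1 (19 nM) and compound 2 (18 nM) lie within the scatter of each other.

Compound 4 `COc1ccc2c(c1)CCN2c1nc(C)nc2ccccc12` keeps the core of compound 3 and differs in one place: methyl in place of chloro on an aromatic carbon between two ring nitrogen atoms. Compound 1 and compound 2 also carry the methyl, but their core differs from that of compound 3 as well. Among the measured compounds shown here, the gap between their values and that of compound 3 therefore cannot be assigned to the chloro alone, and no measured pair isolates this change.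

In this assay a modest move to a lower number is expected, only a little beyond the scatter. This expected move is smaller than the gap that separates compound 3 from compound 1 (19 nM). The expected step is a 2.5-fold lower number from compound 3 to compound 4 (0.40 log units; beyond the scatter) and remains uncertain. The estimate for compound 4 is 90 nM with an expected range from 25 nM to 300 nM.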

Compound 4, concentration for 50% growth inhibition: 320 nM
The estimate for compound 4 lay 3.6-fold (0.55 log units) below the measured number; the measured number lies above the stated range.
By their numbers in this assay, from the lowest: compounds 2 and 1 (each within the scatter of the next); then compounds 3 and 4 (each within the scatter of the next).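

In this assay, exchanging chloro for methyl on the aromatic carbon between two ring nitrogen atoms gives a 1.4-fold higher number from compound 3 to compound 4 (0.15 log units; within the scatter), so the two groups cannot be told apart at this position in this core. Among the compounds shown here, this is the first pair that isolates the change, and it shows that the methyl alone does not account for the gap between compound 3 and the two methyl-bearing compounds, compound 1 and compound 2, whose core differs. No measurement on these compounds bears on why chloro and methyl read alike here.

Going by these compounds, whether any other group at this aromatic carbon, such as an amine, a methoxy or a longer chain, would move the number beyond the scatter remains open, since two groups of one heavy atom each sample this position only narrowly. Also open, on these data alone, is which feature of the core of compound 1 and compound 2 goes with their lower numbers, and whether chloro and methyl would also read alike on that core.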